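The source may report more compounds than this note shows. Statements on the series, on what has been measured and on what is new or still open speak of the compounds shown alone.

Compound 1 `Clc1ccccc1-c1n[nH]cc1N1CCNCC1` and compound 3 `Fc1ccccc1-c1n[nH]cc1N1CCNCC1` share one core, while compound 2 `Clc1cccc(-c2n[nH]cc2N2CCNCC2)c1` is built from the same atoms joined differently; how the cores of compound 2 and compound 1 differ is not broken down here. In an assay on isolated protein for binding affinity to 5-hydroxytryptamine receptor 1E (Homo sapiens) (a higher number here means a weaker inhibitor, a lower number a stronger inhibitor), compound 1 gives only a limit, > 10000 nM. In this assay compound 2 likewise gives only a limit, > 10000 nM. In this assay compound 3 also gives only a limit, > 10000 nM. The step that the two limits leave unreadable from compound 1 to compound 3 thus stays unreadable, the change being (fluoro in place of chloro on an aromatic carbon). Compound 4 `Fc1cccc(-c2n[nH]cc2N2CCNCC2)c1` arises from compound 2 by the same kind of change, (fluoro in place of chloro on an aromatic carbon), its place reading "meta to a large group" where the earlier one reads "ortho to a large group". Because every measured value sits at the limit of > 10000 nM in this assay, at which 3 of the 3 values shown sit, compound 4 is expected to give 20000 nM, an estimated step that the limit leaves unreadable from compound 2 to compound 4, most probably again only a limit.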

Compound 4, inhibition constant: > 10000 nM
Compound 4: no number, only a limit; the forecaster's own chance of this, stated with the estimate: 85%; the middle value lies beyond the limit too.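

Compound 2 and compound 4 both give only limits in this assay, so the step between them cannot be read. The compounds shown leave open whether any of these structures would give a readable value: the limit of > 10000 nM in this assay, at which 4 of the 4 values shown sit.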